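Working notes: methoxy added on the aryl ketone, compound 2 to compound 3

The source may hold more compounds than are shown below. What is called first, only, known or untested is meant among the compounds shown, and "the series" means these compounds.

Measured so far in a functional assay on NCI-H522 cells (Homo sapiens) for inhibition, read by sulforhodamine B assay, with a stated time of 48 h; on this read-out higher numbers stand for weaker inhibition of growth and lower numbers for stronger inhibition of growth:
compound 1 `COc1cc(-c2cc(/C=C/C(=O)c3ccc(Cl)c(Cl)c3)[nH]n2)cc(OC)c1OC` gives 3040 nM
compound 2 `COc1ccc(C(=O)/C=C/c2cc(-c3cc(OC)c(OC)c(OC)c3)n[nH]2)cc1` gives 3200 nM

Compound 2 holds the higher of the two numbers, but its gap to compound 1 is within the scatter: a 1.1-fold higher number from compound 1 to compound 2 (0.02 log units; within the scatter), a change of the aryl group on the carbonyl carbon, moved nothing beyond noise.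

Compound 3 `COc1ccc(C(=O)/C=C/c2cc(-c3cc(OC)c(OC)c(OC)c3)n[nH]2)cc1OC` differs from compound 2 by methoxy in place of hydrogen on an aromatic carbon. Among the measured compounds shown here, no measured step adds a methoxy; the only change on that aryl group was within the scatter. The step of no change at the digits printed from compound 2 to compound 3 (within the scatter) is therefore expected to stay within the scatter. Compound 3 is estimated at 3200 nM, range 1300 nM to 8000 nM.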

Compound 3, concentration for total growth inhibition: 390 nM
The estimate for compound 3 lay 8.2-fold (0.91 log units) above the measured number, outside the stated range (below it).
By their numbers in this assay, from the lowest: compound 3; then compounds 1 and 2 (each within the scatter of the next).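

In this assay, this aromatic carbon of the aryl ketone responds to substitution: methoxy in place of hydrogen gives an 8.2-fold lower number from compound 2 to compound 3 (0.91 log units; beyond the scatter), a change beyond the scatter that the earlier aryl swap, a 1.1-fold higher number from compound 1 to compound 2 (0.02 log units; within the scatter), did not reveal. The 3,4-dimethoxyphenyl group also separates from 3,4-dichlorophenyl, with a 7.8-fold lower number from compound 1 to compound 3 (0.89 log units; beyond the scatter), so among these three compounds only the 3,4-dimethoxyphenyl ketone stands apart. No evidence on hand accounts for this step.

Left open is whether a hydroxy group, an ethoxy group or an amine on the same aromatic carbon would keep the step.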